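A few compounds are considered here, and "the series" means these few. Any claim that something is new, unique, unknown or untested is made for them only; others in the source may bear on it.

Within the data shown here, in a physicochemical assay for solubility, with a stated time of 24 h, tested at 30 mg/mL (a lower number here means a less soluble compound, a higher number a more soluble compound), compound 2 `Cc1cc(COc2ccc(S(=O)(=O)NC3(C(=O)NO)CC3)cc2)c2ccccc2n1` gives 46000000 nM, the higher of the two numbers measured so far. Among the measured compounds shown here, the only other measured compound, compound 1 `Cc1cc(COc2ccc(S(=O)(=O)NC3(CC(=O)NO)CC3)cc2)c2ccccc2n1`, gives 1600000 nM. The next compound, compound 3 `Cc1cc(COc2ccc(S(=O)(=O)NC3(C(=O)NO)CCCC3)cc2)c2ccccc2n1`, differs from compound 2 at one place: a group of 9 heavy atoms (6 carbon, 1 nitrogen, 2 oxygen; one five-membered non-aromatic ring of carbon only) in place of a group of 7 heavy atoms (4 carbon, 1 nitrogen, 2 oxygen; one three-membered non-aromatic ring of carbon only), on a sulfonamide nitrogen. Its three-membered non-aromatic ring of carbon only thus gives way to a five-membered one. For the measured compounds named here, no measured step changes this ring, so the evidence is indirect. Going by the values given here, the single step available is a 29-fold higher number from compound 1 to compound 2 (1.46 log units; beyond the scatter), a large one, in which hydroxycarbamoyl stands in place of (hydroxycarbamoyl)methyl on a saturated ring carbon. That step concerns a different change, but the compound with the larger group has the lower number there. One pair establishes no rule, so it supports only a tentative expectation of a lower number in this assay for the larger ring. The expected change is a 5.8-fold lower number from compound 2 to compound 3 (0.76 log units; beyond the scatter), a moderate to large drop with wide uncertainty. For compound 3, the estimated value is 8000000 nM, with an expected range from 1200000 nM to 40000000 nM.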

Compound 3, solubility: 200000 nM
Estimate against measurement, compound 3: 40-fold (1.60 log units) above; the whole stated range lies above it.
By their numbers in this assay, from the lowest: compound 3; then compound 1; then compound 2.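

In this assay, the ring on the sulfonamide nitrogen turns out to matter strongly: with hydroxycarbamoyl kept in place, a five-membered ring of carbon only in place of a three-membered one gives a 230-fold lower number from compound 2 to compound 3 (2.36 log units; beyond the scatter), a larger step than the earlier change from (hydroxycarbamoyl)methyl to hydroxycarbamoyl. Compound 3 also falls short of the compound with the three-membered ring and (hydroxycarbamoyl)methyl, with an 8.0-fold lower number from compound 1 to compound 3 (0.90 log units; beyond the scatter), so across these three compounds the number falls as the group on that nitrogen gains heavy atoms, and none goes against this order, though three compounds make only a slender pattern. Nothing available accounts for the size of the drop.

The compounds shown leave open whether this order holds for a four-membered or six-membered ring of carbon only, or for a ring containing oxygen or nitrogen, such as a tetrahydropyran or a piperidine. They also leave open how (hydroxycarbamoyl)methyl or a carboxylic acid would behave on the five-membered ring, which would show whether the ring and the group on it act independently.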